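The source may report more compounds than this note shows. Statements on the series, on what has been measured and on what is new or still open speak of the compounds shown alone.

Compound 2 `Oc1ccc(-c2cc(-c3cccc(Cl)c3)nc(-c3cccs3)c2)cc1` stands highest of the two numbers measured in an assay on isolated protein for inhibition of DNA topoisomerase 1 (Homo sapiens), with a stated time of 30 min, tested at 100 uM (a lower number here means a weaker effect, a higher number a stronger effect of the compound at the concentration tested), giving 52.4%. Compound 1 `Oc1ccc(-c2cc(-c3cccs3)nc(-c3ccccc3Cl)c2)cc1` gives 2.2% in this assay. Among the measured compounds shown here, the single measured step, a number 50.2 percentage points higher from compound 1 to compound 2 (beyond the scatter), concerns only the chlorophenyl group and tells nothing about the thiophene. Compound 3 `Oc1ccc(-c2cc(-c3ccsc3)nc(-c3cccc(Cl)c3)c2)cc1` differs from compound 2 by thiophen-3-yl in place of thiophen-2-yl on an aromatic carbon. For the measured compounds named here, no measured step bears on this exchange, and the expected step of a number 2.4 percentage points lower from compound 2 to compound 3 (within the scatter) is none beyond the scatter. Compound 3 is estimated at 50% in this assay, with a range from 25% to 72%.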

Compound 3, a percentage reported as inhibition, at one concentration (the size of the read-out at that concentration, not a potency): 26%
Compound 3: middle estimate off by 24 percentage points, on the high side; low and high end bracket the measured number.
By their numbers in this assay, from the lowest: compound 1; then compound 3; then compound 2.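

Thiophen-3-yl in place of thiophen-2-yl, next to the ring nitrogen, gives a number 26.4 percentage points lower from compound 2 to compound 3 (beyond the scatter) in this assay, although the two groups hold the same atoms and differ only in how they are joined. This position therefore responds to the attachment point of the thiophene alone, whereas the earlier step concerned only the chlorophenyl group. No measured evidence accounts for this step. Still open, from the compounds shown here alone, is whether furan-2-yl or an amine at this place would hold the number, and whether the same thiophene exchange gives a similar step alongside 2-chlorophenyl.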